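Bromo added to the fluorophenyl amide of compound 1

A few compounds are considered here, and "the series" means these few. Any claim that something is new, unique, unknown or untested is made for them only; others in the source may bear on it.

Going by the values given here, compound 1 `CN1C[C@H](C(=O)Nc2ccc(F)cc2)[C@@H](c2ccc(/C=C/C(=O)Nc3ccccc3N)cc2)C1` is read in an in vitro ADME assay on microsomes from liver (Homo sapiens) for pharmacokinetics, read by LC-MS, with a stated time of 10 min, tested at 1 uM (on this read-out lower numbers stand for slow clearance and higher numbers for fast clearance), and gives 5 mL/min/kg; only one other number sits beside it, and that one lies within the scatter of it. Compound 2 `CN1C[C@H](C(=O)Nc2ccc(Br)cc2)[C@@H](c2ccc(/C=C/C(=O)Nc3ccccc3N)cc2)C1`, which carries bromo in place of fluoro on the aromatic carbon, gives 3 mL/min/kg in this assay, so the step of a 1.7-fold lower number from compound 1 to compound 2 (0.22 log units; within the scatter).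

Compound 3 `CN1C[C@H](C(=O)Nc2ccc(F)c(Br)c2)[C@@H](c2ccc(/C=C/C(=O)Nc3ccccc3N)cc2)C1` differs from compound 1 by bromo in place of hydrogen on an aromatic carbon. Among the compounds with values here, the only measured step that bears on it is the exchange of fluoro for bromo on the same ring, and that step stayed within the scatter. Within the data shown here, nothing among the measured numbers points in either direction for an added bromo beside the retained fluoro.

For compound 3 the expected step is therefore a 1.3-fold lower number from compound 1 to compound 3 (0.10 log units; within the scatter), none beyond the scatter. Compound 3 is estimated at 4 mL/min/kg, with a range from 2 mL/min/kg to 9 mL/min/kg.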

Compound 3, clearance: 15 mL/min/kg
Compound 3: the middle estimate sits 3.8-fold (0.57 log units) below what was measured; the measured number lies above the stated range.
By their numbers in this assay, from the lowest: compounds 2 and 1 (each within the scatter of the next); then compound 3.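

In this assay, the change from 4-fluorophenyl to 3-bromo-4-fluorophenyl gives a 3.0-fold higher number from compound 1 to compound 3 (0.48 log units; beyond the scatter), so this ring carbon, ortho to a fluoro group, is a place where an added bromo moves the read-out beyond the scatter, which the earlier exchange of fluoro for bromo did not do. The comparison with the 4-bromophenyl amide points the same way, with 3-bromo-4-fluorophenyl in place of 4-bromophenyl giving a 5.0-fold higher number from compound 2 to compound 3 (0.70 log units; beyond the scatter), so the two bromo-bearing compounds are separated beyond the scatter. No measurement in hand gives a reason for this rise.

Going by these compounds, whether a smaller or different group on the same carbon, such as chloro, methoxy or a nitrile, gives a comparable rise remains open. Also open, on these data alone, is whether the rise depends on the retained fluoro, a question a 3-bromophenyl amide would address.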